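The source may report more compounds than this note shows. Statements on the series, on what has been measured and on what is new or still open speak of the compounds shown alone.

Measured so far:
compound 1, `COc1cccc(/C=N/NC(=O)c2ccc(C)cc2O)c1` — 672000 nM
compound 2, `Cc1ccc(C(=O)N/N=C/c2cc(Cl)ccc2O)c(O)c1` — 560000 nM

In an ADME assay on cells (Mus musculus, strain BALB/C) for cytotoxicity, read by MTT assay, with a stated time of 24 h (a lower number here means that less compound is tolerated, a higher number that more compound is tolerated), compound 1 gives 672000 nM and compound 2 gives 560000 nM. Compound 2 carries the lowest of the two numbers, but its nearest neighbour is compound 1, and the gap between them lies within the scatter, so the two values show no difference that can be read as order.

Compound 3, `Cc1ccc(C(=O)N/N=C/c2cccc(Cl)c2)c(O)c1`, has not yet been measured in this assay. It differs from compound 2 in one place: hydrogen in place of hydroxy on an aromatic carbon. Nothing measured so far separates a hydroxy from a hydrogen at this position, so there is no shown step to lean on.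

The expected step from compound 2 to compound 3 in this assay is a 1.1-fold lower number from compound 2 to compound 3 (0.05 log units; within the scatter), a change not expected to reach beyond the scatter. Compound 3 is therefore estimated at 500000 nM, with a range from 250000 nM to 1000000 nM.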

Compound 3, half-maximal cytotoxic concentration: 636000 nM
Estimate against measurement, compound 3: 1.3-fold (0.10 log units) below, within the range that was stated.
By their numbers in this assay, from the lowest: compounds 2, 3 and 1 (each within the scatter of the next).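

In this assay, the hydroxy that sits ortho to a large group and para to a chloro group can be replaced by hydrogen with a step of a 1.1-fold higher number from compound 2 to compound 3 (0.06 log units; within the scatter), so this position shows no separation between the two on this read-out. Going by these compounds alone, the same compound gives the first reading of chloro in place of methoxy on an aromatic carbon, a 1.1-fold lower number from compound 1 to compound 3 (0.02 log units; within the scatter), and that change likewise shows no difference that can be read. No measurement at hand explains why either change leaves the number within the scatter.

As far as these compounds go, whether an amine or a carboxylic acid on this aromatic carbon would give a number beyond the scatter stays open. So does whether hydrogen in place of hydroxy would give so small a step in a compound without the chloro group.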